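Estimating Compound 4 from Three Measured Analogues

The source may hold more compounds than are shown below. What is called first, only, known or untested is meant among the compounds shown, and "the series" means these compounds.

Compound 1 `C/C(=N\NC(=O)c1cccc(S(=O)(=O)N2CCOCC2)c1)c1cccc(N)c1` gives in a functional assay on MGC-803 cells (Homo sapiens) for antiproliferative activity, read by MTT assay, with a stated time of 72 h (a lower number here means a stronger inhibitor, a higher number a weaker inhibitor), only a limit of the assay, > 100000 nM.
Compound 2 `C/C(=N\NC(=O)c1cccc(S(=O)(=O)N2CCOCC2)c1)c1ccc(F)cc1` gives in this assay likewise only a limit, > 100000 nM.
Compound 3 `C/C(=N\NC(=O)c1cccc(S(=O)(=O)N2CCOCC2)c1)c1ccc(O)cc1` gives in this assay 71400 nM.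

Among the measured compounds shown here, compound 3 thus holds the only number among the three; the other two sit at the limit of > 100000 nM in this assay, at which 2 of the 3 values shown sit. Compound 4 `C/C(=N\NC(=O)c1cccc(S(=O)(=O)N2CCOCC2)c1)c1cccc(N)c1O` differs from compound 3 by 3-amino-2-hydroxyphenyl in place of 4-hydroxyphenyl on a carbon with a double bond to nitrogen. The measured steps that bear on this change are an at least 1.4-fold lower number from compound 1 to compound 3 (0.14 log units; that floor lies within the scatter) and an at least 1.4-fold lower number from compound 2 to compound 3 (0.14 log units; that floor lies within the scatter), each only a floor lying within the scatter, while a step that the two limits leave unreadable from compound 1 to compound 2. Compound 4 carries the amino group seen in compound 1, which gave > 100000 nM, together with a hydroxy group like compound 3, which gave 71400 nM. Compound 4 is therefore expected to stay weak, with a 1.1-fold higher number from compound 3 to compound 4 (0.05 log units; within the scatter) not beyond the scatter. Compound 4 is estimated at 80000 nM, between 30000 nM and 200000 nM.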

Compound 4, half-maximal inhibitory concentration: 530 nM
Beside the measured number, compound 4's estimate is 150-fold (2.18 log units) above it, outside the stated range (below it).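

In this assay, among the compounds shown here, 3-amino-2-hydroxyphenyl on the carbon with a double bond to nitrogen brings a 130-fold lower number from compound 3 to compound 4 (2.13 log units; beyond the scatter), showing that this position can support far stronger activity than the earlier compounds revealed. Hydroxy in place of hydrogen on an aromatic carbon brings an at least 180-fold lower number from compound 1 to compound 4 (2.27 log units; beyond the scatter), and the change from 4-fluorophenyl brings an at least 180-fold lower number from compound 2 to compound 4 (2.27 log units; beyond the scatter). These two steps start from a limit of the assay, not a number: the limit of > 100000 nM in this assay, at which 2 of the 4 values shown sit.

The compounds shown leave open how much of the gain depends on the free hydroxy and amino groups together. Whether a methoxy group in place of the hydroxy, or an acetamide in place of the amino group, would keep this activity also remains unanswered.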